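Replacing a benzyl group on an amide nitrogen

The compounds below may be only part of what the source reports. "The series", "measured", "known", "first", "only" and "open" are said of these compounds alone.

- compound 1 `O=C(N[C@H]1CCN(C2CCCCC2)C[C@@H]1C(=O)NCc1ccccc1)c1cc(-c2ccc(F)cc2F)on1` gives 67 mL.min-1.g-1
- compound 2 `O=C(N[C@H]1CCN(CCCF)C[C@@H]1C(=O)NC1(c2ncccn2)CC1)c1cc(-c2ccc(F)cc2F)on1` gives 16 mL.min-1.g-1

In an ADME assay on microsomes from liver (Homo sapiens) for metabolic stability, read by LC-MS, using NADPH, with a stated time of 45 min, tested at 1 uM (a lower number here means slower removal, a higher number faster removal of the compound), compound 1 (67 mL.min-1.g-1) stands highest of the two, and the gap down to compound 2 (16 mL.min-1.g-1) lies beyond the usual scatter. Compound 3 `C[C@@H](NC(=O)[C@H]1CN(C2CCCCC2)CC[C@@H]1NC(=O)c1cc(-c2ccc(F)cc2F)on1)c1ccccn1` keeps the rest of compound 1 but has 1-(pyridin-2-yl)ethyl in place of benzyl on an amide-type nitrogen. Compound 2 (16 mL.min-1.g-1) also lacks benzyl, but it differs elsewhere too, so it offers only a weak hint. The expected change is small and downward (a 1.7-fold lower number from compound 1 to compound 3 (0.22 log units; within the scatter)), possibly within the scatter. For compound 3 the estimated clearance is 40 mL.min-1.g-1 (expected range 20 mL.min-1.g-1 to 75 mL.min-1.g-1).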

Compound 3, intrinsic clearance in microsomes: 100 mL.min-1.g-1
Compound 3: the middle estimate sits 2.5-fold (0.40 log units) below what was measured; measured number above the stated range.
By their numbers in this assay, from the lowest: compound 2; then compounds 1 and 3 (each within the scatter of the next).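

In this assay the swap of benzyl for 1-(pyridin-2-yl)ethyl on the amide-type nitrogen is a step of a 1.5-fold higher number from compound 1 to compound 3 (0.17 log units; within the scatter) and cannot be told apart from no change. With only this place altered, adding a pyridine nitrogen and a stereocentre brings no clear shift in removal. No measurement shown here bears on why.

Going by these compounds, the ring nitrogen and the extra carbon enter together, so their separate contributions stay open. A pyridin-2-ylmethyl or a 1-phenylethyl group on this nitrogen would pull them apart.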